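A few compounds are considered here, and "the series" means these few. Any claim that something is new, unique, unknown or untested is made for them only; others in the source may bear on it.

Compound 2 `Cc1ccc(N2C(=O)C/C(=C\c3cccc(C(=O)Nc4ccc(Cl)cc4)c3)C2=O)cc1` is one of two close relatives examined in an ADME assay on HCT-116 cells (Homo sapiens) for cytotoxicity, read by MTT assay, with a stated time of 72 h; a lower number here means a stronger inhibitor, a higher number a weaker inhibitor. Compound 1 `Cc1ccc(N2C(=O)C/C(=C\c3cccc(C(=O)Nc4cccc(F)c4)c3)C2=O)cc1` differs from it only at the amide-type nitrogen, where it carries 3-fluorophenyl in place of 4-chlorophenyl. In this assay compound 1 gives > 100000 nM, which is a limit of the assay and not a number. In this assay compound 2 gives > 100000 nM, again a limit rather than a number. The step that the two limits leave unreadable from compound 1 to compound 2 therefore cannot be read in size. Where compound 2 stands is known only as a limit, and the other value shown is also one (the limit of > 100000 nM in this assay, at which 2 of the 2 values shown sit).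

Compound 3 `COc1ccc(NC(=O)c2cccc(/C=C3\CC(=O)N(c4ccc(C)cc4)C3=O)c2)cc1` has not yet been measured. It differs from compound 2 by methoxy in place of chloro on an aromatic carbon. Within the data shown here, the single measured step, from compound 1 to compound 2, concerns a change on the same amide-type nitrogen, but its size is unreadable, so no measured step gives a direction or size for the change to methoxy. In this assay the step of a number no higher from compound 2 to compound 3 (the limit leaves the size open) is expected, meaning nothing beyond the scatter. Compound 3 is accordingly estimated at 100000 nM in this assay, within 30000 nM to 300000 nM, and most likely reported again only as a limit.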

Compound 3, half-maximal inhibitory concentration: > 100000 nM
Compound 3 gave a limit, no number; the forecaster's own chance of this, stated with the estimate: 80%; the middle value lies on the limit itself.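

Compound 3, like compound 1 and compound 2, gives only a limit in this assay and not a number, so no step among these three compounds can be read in size: the limit of > 100000 nM in this assay, at which 3 of the 3 values shown sit. The compounds shown leave open how the 3-fluorophenyl, 4-chlorophenyl and 4-methoxyphenyl compounds would compare if actual numbers were available.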